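This account rests on a few compounds, and the source may have more. Where it says the series, first, only, none or still open, it means among the compounds named here.

Measured compounds:
Compound 1 `Cc1cn(COCCO)c(=O)[nH]c1=O` in a functional assay on L1210 cells (Mus musculus) for inhibition (on this read-out higher numbers stand for weaker inhibition and lower numbers for stronger inhibition), gives > 1000 ug/mL.
Compound 2 `Nc1nc2c(nc(Cl)n2COCCO)c(=O)[nH]1` in this assay gives > 1000 ug/mL.

Both values are limits of the assay and not numbers. Going by the values given here, compound 2 therefore stands at the limit, the same place where every value shown sits (the limit of > 1000 ug/mL in this assay, at which 2 of the 2 values shown sit); no compound has yet given a measured number, and no step between measured compounds exists to set a scale.

Compound 3 `CNc1nc2c(=O)[nH]c(N)nc2n1COCCO` is not yet measured. Against compound 2 the change is methylamino in place of chloro on an aromatic carbon.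

With both recorded values sitting at the limit, nothing here points to a shift of any size, so the expectation is no step beyond the scatter, the most likely outcome being a further limit rather than a number. The estimated step from compound 2 to compound 3 is a number no higher from compound 2 to compound 3 (the limit leaves the size open). Compound 3 is accordingly expected to give about 1000 ug/mL, in the range 300 ug/mL to 3000 ug/mL.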

Compound 3, concentration for 50% inhibition: > 500 ug/mL
Compound 3 ended at the assay's limit (the forecaster's own chance of this, stated with the estimate: 80%); the middle value is on the limit's open side.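

The values of compound 2 and compound 3 are both limits in this assay, and no step can be read between them for methylamino in place of chloro. Still open is whether any compound shown would give a measured number, and what size of step this change carries.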